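A few compounds are considered here, and "the series" means these few. Any claim that something is new, unique, unknown or untested is made for them only; others in the source may bear on it.

Measured so far:
compound 1 `O=S(=O)(c1ccccc1)n1ccc2ccc(-c3ccccc3)cc21`, 178 nM in an assay on isolated protein for displacement of a labelled ligand from 5-hydroxytryptamine receptor 6 (Homo sapiens), read by scintillation counting, with a stated time of 1 h; on this read-out higher numbers stand for weaker inhibition and lower numbers for stronger inhibition
compound 2 `O=S(=O)(c1ccccc1)n1ccc2ccc(-c3ccncc3)cc21`, 38 nM in this assay

Compound 2 gives the lowest number of the two; its nearest neighbour is compound 1, reached by a 4.7-fold lower number from compound 1 to compound 2 (0.67 log units; beyond the scatter), a change on an aromatic carbon. Compound 3 `CS(=O)(=O)n1ccc2ccc(-c3ccncc3)cc21` differs from compound 2 by methyl in place of phenyl on a sulfonyl sulfur. Among the measured compounds shown here, no measured step touches the sulfonyl sulfur, so the one known step gives no direct guide for this change. A step of uncertain direction is expected, likely a moderate rise in the number, so that compound 3 is estimated at 150 nM in this assay, within 40 nM to 600 nM, that is a 3.9-fold higher number from compound 2 to compound 3 (0.60 log units; beyond the scatter).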

Compound 3, inhibition constant: 4050 nM
Estimate against measurement, compound 3: 27-fold (1.43 log units) below, outside the stated range (above it).
By their numbers in this assay, from the lowest: compound 2; then compound 1; then compound 3.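

The sulfonyl sulfur proves far more sensitive than the aromatic carbon in this assay: with pyridin-4-yl held constant, methyl in place of phenyl gives a 110-fold higher number from compound 2 to compound 3 (2.03 log units; beyond the scatter), a much larger step than a 4.7-fold lower number from compound 1 to compound 2 (0.67 log units; beyond the scatter). Pyridin-4-yl therefore does not keep the number low once phenyl on the sulfonyl sulfur is gone. No supporting measurement explains this loss.

Open, as far as these compounds go, is how an ethyl group, a longer alkyl chain or a benzyl group on the sulfonyl sulfur would compare. Also open, from the compounds shown here alone, is whether the same step appears with phenyl on the aromatic carbon.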